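Benzoxazole and benzothiazole piperazine oxadiazoles on HepG2 cells

The compounds below may be only part of what the source reports. "The series", "measured", "known", "first", "only" and "open" are said of these compounds alone.

In a functional assay on HepG2 cells (Homo sapiens) for inhibition, read by MTT assay, with a stated time of 72 h (a higher number here means a weaker inhibitor, a lower number a stronger inhibitor), compound 1 `c1ccc(-c2nnc(SCCCN3CCN(c4nc5ccccc5o4)CC3)o2)cc1` gives 102000 nM. Compound 2 `O=C(NCc1nnc(SCCCN2CCN(c3nc4ccccc4o3)CC2)o1)c1ccccc1` gives 88900 nM in this assay. The change between them, (benzamidomethyl in place of phenyl on an aromatic carbon), made a step of a 1.1-fold lower number from compound 1 to compound 2 (0.06 log units; within the scatter). Compound 3 `c1ccc(-c2nnc(SCCCN3CCN(c4nc5ccccc5s4)CC3)o2)cc1` gives 217000 nM in this assay; its core differs from that of compound 1 by 1,3-benzothiazol-2-yl in place of 1,3-benzoxazol-2-yl on an amine nitrogen in a ring, a step of a 2.1-fold higher number from compound 1 to compound 3 (0.33 log units; beyond the scatter), and its number is the highest of the three. Compound 4 `O=C(NCc1nnc(SCCCN2CCN(c3nc4ccccc4s3)CC2)o1)c1ccccc1` has not been measured. It differs from compound 3 by benzamidomethyl in place of phenyl on an aromatic carbon, the same change as from compound 1 to compound 2, at a place described in the same words. For compound 4 the expected step in this assay is a 1.1-fold lower number from compound 3 to compound 4 (0.05 log units; within the scatter), resting on a 1.1-fold lower number from compound 1 to compound 2 (0.06 log units; within the scatter) seen for the same change on the core of compound 1. Compound 4 is therefore estimated at 195000 nM, with a range from 100000 nM to 400000 nM.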

Compound 4, half-maximal inhibitory concentration: 325000 nM
Beside the measured number, compound 4's estimate is 1.7-fold (0.22 log units) below it, within the range that was stated.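

In this assay, benzamidomethyl in place of phenyl gives a 1.5-fold higher number from compound 3 to compound 4 (0.18 log units; within the scatter), and this agrees with the same change on the core of compound 1: the same change on two cores in this assay, a 1.1-fold lower number (0.06 log units; within the scatter) from compound 1 to compound 2 and a 1.5-fold higher number (0.18 log units; within the scatter) from compound 3 to compound 4, 1.7-fold (0.24 log units) apart, within the scatter of two such steps. The change to 1,3-benzothiazol-2-yl from 1,3-benzoxazol-2-yl also carries across, here as a 3.7-fold higher number from compound 2 to compound 4 (0.56 log units; beyond the scatter): the same change on two cores in this assay, a 2.1-fold higher number (0.33 log units; beyond the scatter) from compound 1 to compound 3 and a 3.7-fold higher number (0.56 log units; beyond the scatter) from compound 2 to compound 4, 1.7-fold (0.24 log units) apart, within the scatter of two such steps. Within the data shown here, each change has been seen on only two cores, so this shows agreement for these four compounds only and does not show that either step would hold on other cores or what lies behind it.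

As far as these compounds go, whether an amine or a carboxylic acid in place of phenyl, or a longer linking chain, would move the number beyond the scatter remains open.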